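Acetyl for Methylsulfonyl on the Ring Amine Nitrogen

The source may report more compounds than this note shows. Statements on the series, on what has been measured and on what is new or still open speak of the compounds shown alone.

For the measured compounds named here, compound 3 `CC(C)Nc1nc2c(nc1N1CCC(Oc3ccc(F)cc3F)CC1)C=CN(S(C)(=O)=O)C2` stands second highest of the three numbers so far in a functional assay on CHO-K1 cells for agonist activity at G-protein coupled receptor 6 (Homo sapiens), read by TR-FRET and cAMP accumulation, with a stated time of 20 h (on this read-out higher numbers stand for an effect only at larger amounts of compound and lower numbers for an effect already at smaller amounts), where compound 3 gives 65000 nM. Compound 2 `CC(C)Nc1nc2c(nc1N1CCC(Oc3ccc(F)cc3F)CC1)C=CNC2` gives 100000 nM. Compound 1 `CC(=O)N1C=Cc2nc(NC3CC3)c(N3CCC(Oc4ccc(F)cc4F)CC3)nc2C1` also carries acetyl on an amine nitrogen in a ring but differs from compound 3 in a second place as well. In this assay compound 1 gives 34000 nM. Both of these lie within the scatter of compound 3. Compound 4 `CC(=O)N1C=Cc2nc(N3CCC(Oc4ccc(F)cc4F)CC3)c(NC(C)C)nc2C1` is the next step: acetyl in place of methylsulfonyl on an amine nitrogen in a ring. Going by the values given here, only one measured step touches the same amine nitrogen in a ring, a 1.5-fold lower number from compound 2 to compound 3 (0.19 log units; within the scatter), and it stayed within the scatter. Compound 1 and compound 3 differ in two places, so that pair gives no clean reading of the acetyl group alone, though their two values are within the scatter of each other. Nothing seen here points to a move beyond the scatter for compound 4 in this assay, and the expected step is a 1.4-fold lower number from compound 3 to compound 4 (0.16 log units; within the scatter). Compound 4 is estimated at 45000 nM in this assay, with a range of 15000 nM to 100000 nM.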

Compound 4, half-maximal effective concentration: 34000 nM
Estimate against measurement, compound 4: 1.3-fold (0.12 log units) above; the range from low to high includes it.
By their numbers in this assay, from the lowest: compounds 1, 4, 3 and 2 (each within the scatter of the next, the first and the last beyond it).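

Acetyl and methylsulfonyl on the amine nitrogen in a ring are not told apart in this assay (a 1.9-fold lower number from compound 3 to compound 4 (0.28 log units; within the scatter)). Acetyl in place of hydrogen on that nitrogen gives the first step at this position that lies beyond the scatter, though only modestly (a 2.9-fold lower number from compound 2 to compound 4 (0.47 log units; beyond the scatter)), while the methylsulfonyl step stayed within it (a 1.5-fold lower number from compound 2 to compound 3 (0.19 log units; within the scatter)). No measurement bearing on the cause of these steps is at hand.

Open, going by these compounds, is whether a longer acyl chain, a urea or a carboxylic acid on this nitrogen would bring the number far below that of compound 4 (34000 nM). Also open, on these data alone, is whether the step from hydrogen to acetyl would hold on the core of compound 1.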